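A halogen swap on compound 2

The source may hold more compounds than are shown below. What is called first, only, known or untested is meant among the compounds shown, and "the series" means these compounds.

- compound 1 `CCC(=O)N1N=C(C)CC1c1cc(Br)cc(Br)c1O`: 38600 nM
- compound 2 `CC1=NN(S(=O)(=O)c2ccc([N+](=O)[O-])cc2)C(c2cc(Br)cc(Br)c2O)C1`: 40100 nM
- compound 3 `CC1=NN(S(=O)(=O)c2ccc(C)cc2)C(c2cc(Br)cc(Br)c2O)C1`: "not active" (no number reported)

All three compounds were tested in a functional assay on MGC-803 cells (Homo sapiens) for cytotoxicity, read by MTT assay, with a stated time of 48 h; a higher number here means a weaker inhibitor, a lower number a stronger inhibitor. Compound 2 gives 40100 nM and compound 1 gives 38600 nM. These two numbers lie within the usual scatter of each other, so they cannot be ranked, and compound 2 stands level with compound 1. Compound 3 has no number to compare, as it was reported only as "not active" (no number reported).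

The next compound to consider is compound 4 `CC1=NN(S(=O)(=O)c2ccc([N+](=O)[O-])cc2)C(c2cc(Cl)ccc2O)C1`. It keeps the rest of compound 2 but carries 5-chloro-2-hydroxyphenyl in place of 3,5-dibromo-2-hydroxyphenyl on a saturated ring carbon. Among the compounds with values here, all three measured compounds carry the dibromo group, so the data contain no measured example of changing it. With no such guide, only a modest change is expected, with no firm direction. The estimated change is a 1.1-fold lower number from compound 2 to compound 4 (0.06 log units; within the scatter). The uncertainty is wide, and the result for compound 3 "not active" (no number reported) shows that a number is not guaranteed in this assay. For compound 4 the expected value is 35000 nM, with an estimated range from 10000 nM to 100000 nM.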

Compound 4, half-maximal inhibitory concentration: "not active" (no number reported)
Compound 4 has no reported number here; no gap can be computed for the estimate.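

Within the data shown here, compound 4 is reported only as "not active", without a number, so no step between compound 2 and compound 4 can be read in this assay. No available evidence bears on this result. The compounds shown leave open which part of the change from 3,5-dibromo-2-hydroxyphenyl to 5-chloro-2-hydroxyphenyl matters for this outcome.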